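This account rests on a few compounds, and the source may have more. Where it says the series, first, only, none or still open, it means among the compounds named here.

Among the compounds with values here, in a functional assay on A20 cells (Mus musculus) for inhibition, with stated times of 1 h, 16 h and 24 h (on this read-out lower numbers stand for stronger inhibition and higher numbers for weaker inhibition), compound 3 (`N#CC1(NC(=O)[C@@H]2C[C@@H](S(=O)(=O)c3ccccc3)C[C@H]2C(=O)N2CCCCC2)CC1`) gives 5 nM, the lowest of the three numbers so far. Compound 1 (`CC(C)(C#N)NC(=O)[C@@H]1C[C@@H](S(=O)(=O)c2ccccc2)C[C@H]1C(=O)N1CCOCC1`) gives 43 nM, and compound 2 (`N#CC1(NC(=O)[C@@H]2C[C@@H](S(=O)(=O)c3ccccc3)C[C@H]2C(=O)N2CCOCC2)CCC1`) gives 236 nM.

Compound 4 (`N#CC1(NC(=O)[C@@H]2C[C@@H](S(=O)(=O)c3ccccc3)C[C@H]2C(=O)N2CCCC2)CC1`) is compound 3 with a single group exchanged: pyrrolidin-1-yl in place of piperidin-1-yl on a carbonyl carbon. In plain words, pyrrolidin-1-yl stands in place of piperidin-1-yl on a carbonyl carbon, so a five-membered non-aromatic ring replaces a six-membered one.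

Within the data shown here, no measured pair changes this group alone, so the evidence is thin. Among the measured compounds shown here, the only single-change step available, a 5.5-fold higher number from compound 1 to compound 2 (0.74 log units; beyond the scatter), lies at a different place, on an amide-type nitrogen. It shows that one small edit in this set can move the number beyond the scatter, but it gives no direction for the new change. A modest step is therefore the reasonable expectation, and the direction is only a cautious guess. With compound 3 already the lowest of the three, a move toward a higher number seems somewhat more likely than a further drop.

The expected change is a 2.4-fold higher number from compound 3 to compound 4 (0.38 log units; beyond the scatter). For compound 4 the estimated value is 12 nM, with an expected range from 4 nM to 40 nM.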

Compound 4, half-maximal inhibitory concentration: 29 nM
Compound 4: middle estimate off by 2.4-fold (0.38 log units), on the low side; low and high end bracket the measured number.
By their numbers in this assay, from the lowest: compound 3; then compounds 4 and 1 (each within the scatter of the next); then compound 2.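

Within the data shown here, this is the first measured change on the carbonyl carbon, and in this assay it shows that this place responds to a small edit: exchanging piperidin-1-yl for pyrrolidin-1-yl gives a 5.8-fold higher number from compound 3 to compound 4 (0.76 log units; beyond the scatter). Among these compounds, until now, the only single-change step lay on the amide-type nitrogen, so the ring on the carbonyl carbon could have had little effect on the number; instead, both places give a modest step beyond the scatter, and here the six-membered ring gives the lower number of the pair. Nothing measured here explains why one ring fits this read-out better than the other.

From the compounds shown here alone, a single pair of rings gives two points and no trend, so it remains open whether azepan-1-yl, with its seven-membered ring, or an open-chain group such as diethylamino on the same carbonyl carbon would give a lower or a higher number. Going by these compounds, it is also open whether this ring exchange would give a step of similar size and direction with 1-cyano-1-methylethyl or 1-cyanocyclobutyl on the amide-type nitrogen.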